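The source may report more compounds than this note shows. Statements on the series, on what has been measured and on what is new or still open speak of the compounds shown alone.

Within the data shown here, in an assay on HEK293 cells for inhibition of acid ceramidase (Homo sapiens), read by fluorescence, with stated times of 10 min and 3 h (a higher number here means a weaker inhibitor, a lower number a stronger inhibitor), compound 2 `CC(=O)N1CCC(c2ccc3c(c2)oc(=O)n3C(=O)NCCCCc2ccccc2)CC1` gives 64 nM, the lowest of the two numbers measured so far; compound 1 `CC(C)N1CCN(c2ccc3c(c2)oc(=O)n3C(=O)NCCCCc2ccccc2)CC1` gives 211 nM in this assay. Among the measured compounds shown here, the single measured step, a 3.3-fold lower number from compound 1 to compound 2 (0.52 log units; beyond the scatter), exchanges one six-membered non-aromatic ring for another. Compound 3 `O=C(NCCCCc1ccccc1)n1c(=O)oc2cc(C3CCCCC3)ccc21` differs from compound 2 by cyclohexyl in place of 1-acetylpiperidin-4-yl on an aromatic carbon. For the measured compounds named here, no measured step tests the loss of the hydrogen-bond acceptor, so the expected step of a 1.6-fold higher number from compound 2 to compound 3 (0.19 log units; within the scatter) is small, leaning toward a slightly higher number. Compound 3 is therefore expected to give about 100 nM in this assay, within a range from 30 nM to 400 nM.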

Compound 3, half-maximal inhibitory concentration: 89 nM
Compound 3: the middle estimate sits 1.1-fold (0.05 log units) above what was measured; the measured number falls inside the stated range.
By their numbers in this assay, from the lowest: compounds 2 and 3 (each within the scatter of the next); then compound 1.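

Going from the acetylated ring to a ring of carbon only gives a 1.4-fold higher number from compound 2 to compound 3 (0.14 log units; within the scatter), so in this assay this aromatic carbon tolerates losing the ring nitrogen and the hydrogen-bond acceptor without a change beyond the scatter. The other step, a 2.4-fold lower number from compound 1 to compound 3 (0.37 log units; beyond the scatter), shows that 4-isopropylpiperazin-1-yl stays apart from cyclohexyl as well as from 1-acetylpiperidin-4-yl. No measurement available here explains these numbers. Still open, going by these compounds, is how a group outside the six-membered rings, such as a carboxylic acid, a primary amine or a single methyl, would compare on this same aromatic carbon.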